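A few compounds are considered here, and "the series" means these few. Any claim that something is new, unique, unknown or untested is made for them only; others in the source may bear on it.

Measured so far in a functional assay on MCF7 cells (Homo sapiens) for cytotoxicity, read by MTT assay, with a stated time of 72 h; on this read-out lower numbers stand for stronger inhibition and higher numbers for weaker inhibition:
compound 1 `Cc1ccc(-n2nc(C(=O)Nc3ccc(Oc4ncnc5[nH]ccc45)cc3)c(C)cc2=O)cc1`, 3620 nM
compound 2 `Cc1cc(=O)n(-c2ccccc2OC(F)(F)F)nc1C(=O)Nc1ccc(Oc2ncnc3[nH]ccc23)cc1`, 32000 nM
compound 3 `Cc1cc(=O)n(-c2cccc(C(F)(F)F)c2)nc1C(=O)Nc1ccc(Oc2ncnc3[nH]ccc23)cc1`, 4560 nM

Compound 2 stands at the highest number of the three: the step of an 8.8-fold higher number from compound 1 to compound 2 (0.95 log units; beyond the scatter) and the step of a 7.0-fold lower number from compound 2 to compound 3 (0.85 log units; beyond the scatter) both set it apart from the other two beyond the scatter.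

Compound 4 `Cc1cc(=O)n(-c2ccccc2OC(F)(F)F)nc1C(=O)Nc1ccc(Oc2ncnc3[nH]ccc23)c(F)c1` differs from compound 2 by fluoro in place of hydrogen on an aromatic carbon. Within the data shown here, none of the measured steps bears on this change: all three swap the group on the aromatic nitrogen, and none touches the part of the molecule where compound 4 differs from compound 2. Among the measured compounds shown here, with no comparable step to lean on, the expectation is a step of no change at the digits printed from compound 2 to compound 4 (within the scatter), that is, none beyond the scatter. Compound 4 is therefore estimated at 32000 nM, in the range 10000 nM to 100000 nM.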

Compound 4, half-maximal inhibitory concentration: 11700 nM
Estimate against measurement, compound 4: 2.7-fold (0.44 log units) above, within the range that was stated.
By their numbers in this assay, from the lowest: compounds 1 and 3 (each within the scatter of the next); then compound 4; then compound 2.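

Until now only the group on the aromatic nitrogen had changed, but fluoro in place of hydrogen on an aromatic carbon, a single added heavy atom, also moves the result in this assay: a 2.7-fold lower number from compound 2 to compound 4 (0.44 log units; beyond the scatter). This position, ortho to a large group and meta to a large group, therefore affects the read-out too. Nothing measured here explains the shift.

Going by these compounds, it remains open whether fluoro gives a similar step with 4-methylphenyl or 3-(trifluoromethyl)phenyl on the nitrogen. On these data alone, it is also open how chloro, methoxy or an amine would behave at this position.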